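The compounds below may be only part of what the source reports. "The series", "measured", "known", "first", "only" and "open" are said of these compounds alone.

Working notes on the series. Compound 1 `CCOC(=O)C1=C(C)N(c2ccccc2C)C(C)=C(C(=O)OCC)C1c1cn(-c2ccccc2)nc1-c1ccccc1` is measured in an ADME assay on Vero cells (Chlorocebus sabaeus) for cytotoxicity; on this read-out higher numbers stand for weaker inhibition and lower numbers for stronger inhibition. In this assay compound 1 gives > 10 ug/mL, which is a limit of the assay and not a number. Compound 2 `CCOC(=O)C1=C(C)N(c2cccc(C)c2)C(C)=C(C(=O)OCC)C1c1cn(-c2ccccc2)nc1-c1ccccc1` carries the change (3-methylphenyl in place of 2-methylphenyl on an amine nitrogen in a ring). In this assay compound 2 gives > 10 ug/mL, again a limit. The step that the two limits leave unreadable from compound 1 to compound 2 cannot be read, since (the limit of > 10 ug/mL in this assay, at which 3 of the 3 values shown sit). Compound 3 `CC(=O)C1=C(C)N(c2ccccc2C)C(C)=C(C(C)=O)C1c1cn(-c2ccccc2)nc1-c1ccccc1` rests on another core; the difference between the two cores is not broken down here. In this assay compound 3 gives > 10 ug/mL, also a limit. Compound 4 `CC(=O)C1=C(C)N(c2cccc(C)c2)C(C)=C(C(C)=O)C1c1cn(-c2ccccc2)nc1-c1ccccc1` is not yet measured and differs from compound 3 by 3-methylphenyl in place of 2-methylphenyl on an amine nitrogen in a ring, the same kind of change as from compound 1 to compound 2, though here the ring atoms two ring bonds away each bear an acetyl group rather than an ethoxycarbonyl group. Because the limit of > 10 ug/mL in this assay, at which 3 of the 3 values shown sit, no step size is readable, the step that the limit leaves unreadable from compound 3 to compound 4 is expected only as a rough guess. Compound 4 is estimated at 15 ug/mL, most likely reported again as a limit.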

Compound 4, half-maximal inhibitory concentration: > 10 ug/mL
Compound 4 ended at the assay's limit (the forecaster's own chance of this, stated with the estimate: 85%); the middle value does not contradict the limit.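

No step can be read from compound 3 to compound 4, as both values are limits and not numbers: the limit of > 10 ug/mL in this assay, at which 4 of the 4 values shown sit.

The compounds shown leave open whether 3-methylphenyl in place of 2-methylphenyl, or acetyl in place of ethoxycarbonyl, changes cytotoxicity at all.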